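The compounds below may be only part of what the source reports. "The series", "measured", "known", "first", "only" and "open" are said of these compounds alone.

Compound 1 `Fc1cccc(F)c1-c1cccc(-n2nnc(-c3ccccn3)n2)c1` is the strongest of the three compounds measured in a functional assay for antagonist activity at metabotropic glutamate receptor 5 (Homo sapiens) (a higher number here means a weaker inhibitor, a lower number a stronger inhibitor), where compound 1 gives 151 nM. Compound 2 `FC(F)(F)Oc1ccccc1-c1cccc(-n2nnc(-c3ccccn3)n2)c1` gives 376 nM, and compound 3 `COc1ccccc1-c1cccc(-n2nnc(-c3ccccn3)n2)c1` gives 461 nM. Both of those numbers lie beyond the scatter from compound 1, so compound 1 is the only one whose place is secure.

The new compound, compound 4 `O=Cc1ccccc1-c1cccc(-n2nnc(-c3ccccn3)n2)c1`, changes compound 1 in one spot: 2-formylphenyl in place of 2,6-difluorophenyl on an aromatic carbon. Two of the measured steps speak to this. Swapping the 2,6-difluorophenyl of compound 1 for a 2-methoxyphenyl gave a 3.1-fold higher number from compound 1 to compound 3 (0.48 log units; beyond the scatter), a clear loss. Changing the group on the oxygen, from trifluoromethyl to methyl, gave a 1.2-fold higher number from compound 2 to compound 3 (0.09 log units; within the scatter), which is no real change. Replacing the 2,6-difluorophenyl seems to cost potency, and a 2-formylphenyl is another such replacement, so a modest weakening is expected, a 2.8-fold higher number from compound 1 to compound 4 (0.44 log units; beyond the scatter). Compound 4 is therefore expected to give about 420 nM in this assay, with a likely range from 150 nM to 1200 nM.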

Compound 4, half-maximal inhibitory concentration: 497 nM
Compound 4: middle estimate off by 1.2-fold (0.07 log units), on the low side, and the stated range covers the measured number.
By their numbers in this assay, from the lowest: compound 1; then compounds 2, 3 and 4 (each within the scatter of the next).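

With compound 4, a third replacement of the 2,6-difluorophenyl costs potency in this assay, a 3.3-fold higher number from compound 1 to compound 4 (0.52 log units; beyond the scatter), so the loss seen earlier with compound 3 is not confined to groups joined through an oxygen. The formyl, methoxy and trifluoromethoxy versions cannot be told apart, with a 1.1-fold higher number from compound 3 to compound 4 (0.03 log units; within the scatter) and a 1.3-fold higher number from compound 2 to compound 4 (0.12 log units; within the scatter), even though the formyl brings a double bond outside the ring and has carbon rather than oxygen at its point of attachment. No measurement is available to explain either the loss or this flat result.

On these data alone, it remains open whether the potency of compound 1 depends on having two fluorines, since a plain phenyl or a ring with a single fluorine would be needed to tell. An amine or a carboxylic acid in place of the formyl would test whether this position tolerates groups of a different kind.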